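Removing the chloro from compound 1: what the numbers suggest

The compounds below may be only part of what the source reports. "The series", "measured", "known", "first", "only" and "open" are said of these compounds alone.

Compound 1 `O=C(Nc1ccccc1O)C1CCc2ccccc2N1C(=O)c1ccc(Cl)cc1` was tested in a functional assay on NCI-H23 cells (Homo sapiens) for cytotoxicity, read by sulforhodamine B assay, with a stated time of 72 h (a lower number here means a stronger inhibitor of growth, a higher number a weaker inhibitor of growth), where compound 1 gives 19200 nM. That is the highest of the two numbers in hand; its nearest neighbour is compound 2 `O=C(Nc1ccccc1C(F)(F)F)C1CCc2ccccc2N1C(=O)c1ccc(Cl)cc1`, which in this assay gives 307 nM. Among the compounds with values here, the one step joining these two, a 63-fold lower number from compound 1 to compound 2 (1.80 log units; beyond the scatter), replaces a hydroxy with a trifluoromethyl on the ring of the amide part, so it tells what that position tolerates, not what the other end of the molecule does.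

Compound 3 `O=C(Nc1ccccc1O)C1CCc2ccccc2N1C(=O)c1ccccc1` keeps the hydroxy of compound 1 and changes the other end: hydrogen in place of chloro on an aromatic carbon. Within the data shown here, no measured pair touches this position, so the size of the step in this assay cannot be read from a comparable case. In the absence of such a case, the step of a 1.3-fold higher number from compound 1 to compound 3 (0.11 log units; within the scatter) is expected to stay within the scatter, possibly drifting to a somewhat higher number. Compound 3 is therefore estimated at 25000 nM, with a plausible range from 8000 nM to 80000 nM.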

Compound 3, concentration for 50% growth inhibition: 3490 nM
For compound 3 the middle estimate is 7.2-fold (0.86 log units) above the measured one; the whole stated range lies above it.
By their numbers in this assay, from the lowest: compound 2; then compound 3; then compound 1.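

In this assay, the end of the molecule that carries the chloro turns out to matter in its own right: with the hydroxy kept in place, the step is a 5.5-fold lower number from compound 1 to compound 3 (0.74 log units; beyond the scatter) and shows that the bare benzoyl gives the stronger growth inhibition of the two. Within the data shown here, until now, the only step on record, a 63-fold lower number from compound 1 to compound 2 (1.80 log units; beyond the scatter), came from the ring of the amide part and said nothing about this end, so this is the first sign that a single atom on the 4-chlorophenyl ring, para to a large group, can shift the number beyond the scatter, although this step is classed as modest and that one as large. Nothing among the available data explains why losing the chloro lowers the number, and no cause can be given for it.

Among these compounds, whether the same change would also lower the number for compound 2, which has trifluoromethyl instead of hydroxy, stays open, as chloro is the only substituent that compound carries at this position. Also open, from the compounds shown here alone, is how a fluoro, a methoxy or an amine at this same place on the ring would compare with chloro and hydrogen.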